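Replacing Cyano with Acetamido: A Step Not Yet Measured

This account rests on a few compounds, and the source may have more. Where it says the series, first, only, none or still open, it means among the compounds named here.

compound 1 `O=C1/C(=C/c2ccncc2)CN(S(=O)(=O)c2ccc([N+](=O)[O-])cc2)C/C1=C\c1ccccc1C(F)(F)F`: 18600 nM
compound 2 `O=C1/C(=C/c2ccncc2)CN(S(=O)(=O)c2ccc(C(F)(F)F)cc2)C/C1=C\c1ccccc1C(F)(F)F`: 13800 nM
compound 3 `N#Cc1ccc(S(=O)(=O)N2C/C(=C\c3ccncc3)C(=O)/C(=C/c3ccccc3C(F)(F)F)C2)cc1`: 17600 nM

All three values come from an ADME assay on L02 cells (Homo sapiens) for cytotoxicity, read by MTT assay, with a stated time of 24 h; a higher number here means a weaker inhibitor, a lower number a stronger inhibitor. Compound 3, at 17600 nM, cannot be told apart from compound 1 or compound 2. The measured changes are a 1.1-fold lower number from compound 1 to compound 3 (0.02 log units; within the scatter) and a 1.3-fold higher number from compound 2 to compound 3 (0.11 log units; within the scatter), and both lie within the scatter.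

Compound 4 `CC(=O)Nc1ccc(S(=O)(=O)N2C/C(=C\c3ccncc3)C(=O)/C(=C/c3ccccc3C(F)(F)F)C2)cc1` carries acetamido in place of cyano on an aromatic carbon, para to a large group: acetamido in place of cyano on an aromatic carbon. For the measured compounds named here, three measured steps bear on this change, as each exchanges one group on an aromatic carbon. Besides the two above, there is a 1.3-fold lower number from compound 1 to compound 2 (0.13 log units; within the scatter), also within the scatter. Nitro, trifluoromethyl and cyano therefore give values that cannot be separated in these three compounds, and none of the three goes against that reading. Going by the values given here, no measured compound carries acetamido, however, so these steps support the expectation only by extension, and the range must stay wider than the spread seen so far.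

No change beyond the scatter is expected in this assay. The expected change is a 1.1-fold lower number from compound 3 to compound 4 (0.04 log units; within the scatter). For compound 4 the estimated value is 16000 nM, with an expected range from 9000 nM to 28000 nM.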

Compound 4, half-maximal inhibitory concentration: 10100 nM
For compound 4 the middle estimate is 1.6-fold (0.20 log units) above the measured one, within the range that was stated.
By their numbers in this assay, from the lowest: compounds 4, 2, 3 and 1 (each within the scatter of the next).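

In this assay the exchange of cyano for acetamido stays small at this position: the measured change is a 1.7-fold lower number from compound 3 to compound 4 (0.24 log units; within the scatter) and, set against the other two groups, a 1.4-fold lower number from compound 2 to compound 4 (0.14 log units; within the scatter) and a 1.8-fold lower number from compound 1 to compound 4 (0.27 log units; within the scatter). Nitro, trifluoromethyl and cyano alone could not show how this position responds to a group with a hydrogen-bond donor; acetamido brings 1 hydrogen-bond donor where cyano has none and 4 heavy atoms where cyano has 2, and the 4-cyanophenyl to 4-acetamidophenyl exchange still yields no step beyond the scatter among these four compounds. Nothing shown here offers an explanation for these numbers.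

The compounds shown leave open whether a different kind of group on this aromatic carbon, such as a free amine or a carboxylic acid, would give a step beyond the scatter in this assay. They also leave open whether a longer acyl chain in place of the acetyl part of acetamido would do so, and whether the same exchange would read alike with a different group elsewhere on the shared core.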